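The source may report more compounds than this note shows. Statements on the series, on what has been measured and on what is new or still open speak of the compounds shown alone.

Within the data shown here, compound 3 `Cn1nc2c(=O)n(CC3(O)CCN(Cc4ccc(-c5ccsc5Cl)cc4Cl)CC3)cnc2c1-c1ccc(CN)cc1` gives 453 nM in an assay on isolated protein for inhibition of ubiquitin carboxyl-terminal hydrolase 7 (Homo sapiens), with stated times of 30 min and 2 h (on this read-out lower numbers stand for stronger inhibition and higher numbers for weaker inhibition), the second highest of the three numbers so far. Compound 1 `Cn1nc2c(=O)n(CC3(O)CCN(Cc4ccc(-c5ccco5)cc4Cl)CC3)cnc2c1-c1ccc(C(F)(F)F)cc1` sits nearest with 530 nM, within the scatter of compound 3. Compound 2 `Cn1nc2c(=O)n(CC3(O)CCN(Cc4ccc(C5=CCCC5)cc4Cl)CC3)cnc2c1-c1ccc(CN)cc1` lies furthest with 76.9 nM, beyond the scatter. The step to compound 4 `Cn1nc2c(=O)n(CC3(O)CCN(Cc4ccc(-c5ccco5)cc4Cl)CC3)cnc2c1-c1ccc(CN)cc1` is furan-2-yl in place of 2-chlorothiophen-3-yl on an aromatic carbon, on the carbon meta to a chloro group and para to a large group. Among the measured compounds shown here, the only measured step at this carbon is a 5.9-fold higher number from compound 2 to compound 3 (0.77 log units; beyond the scatter), which exchanges a different partner against the same 2-chlorothiophen-3-yl. Compound 1 also carries furan-2-yl, though with another group on the distal aryl ring; its number and that of compound 3 lie within the scatter. A modest fall in the number is expected for compound 4, a 1.8-fold lower number from compound 3 to compound 4 (0.26 log units; within the scatter). Compound 4 is therefore estimated at 250 nM, range 100 nM to 600 nM.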

Compound 4, half-maximal inhibitory concentration: 18.1 nM
For compound 4 the middle estimate is 14-fold (1.14 log units) above the measured one; measured number below the stated range.
By their numbers in this assay, from the lowest: compound 4; then compound 2; then compounds 3 and 1 (each within the scatter of the next).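

On the aromatic carbon para to a large group, the choice of ring matters strongly: in this assay furan-2-yl gives a 25-fold lower number from compound 3 to compound 4 (1.40 log units; beyond the scatter) against 2-chlorothiophen-3-yl and a 4.2-fold lower number from compound 2 to compound 4 (0.63 log units; beyond the scatter) against cyclopent-1-en-1-yl. Compound 4 therefore holds the lowest number of the four. With furan-2-yl kept, aminomethyl in place of trifluoromethyl gives a 29-fold lower number from compound 1 to compound 4 (1.47 log units; beyond the scatter) and thus shows a large contribution from that second site.

Nothing shown explains these gaps. Open, going by these compounds, is whether thiophen-2-yl keeps the low number of compound 4, and whether a carboxylic acid can stand in place of aminomethyl.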